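The source may hold more compounds than are shown below. What is called first, only, known or untested is meant among the compounds shown, and "the series" means these compounds.

Compound 1 `Nc1ncnc2c1c(-c1ccc(Oc3ccccc3)cc1)cn2C[C@H]1CCCN1C[C@@H](O)CO`: 14400 nM
Compound 2 `Nc1ncnc2c1c(-c1ccc(Oc3ccccc3)cc1)cn2C[C@H]1CCCN1C[C@@H]1CO1`: 7040 nM

In a functional assay on Daudi cells (Homo sapiens) for antiproliferative activity (a lower number here means a stronger inhibitor, a higher number a weaker inhibitor), compound 2 gives 7040 nM, the lowest of the two numbers, and compound 1 stands nearest, separated by a 2.0-fold lower number from compound 1 to compound 2 (0.31 log units; beyond the scatter). Compound 3 `Nc1ncnc2c1c(-c1ccc(Oc3ccccc3)cc1)cn2[C@H]1CCN(C[C@@H]2CO2)C1` differs from compound 2 by 1-((oxiran-2-yl)methyl)pyrrolidin-3-yl in place of (1-((oxiran-2-yl)methyl)pyrrolidin-2-yl)methyl on an aromatic nitrogen. Going by the values given here, the one measured step concerns the group on the amine nitrogen, not the link to the aromatic nitrogen, so no measured step bears on this change. With nothing to lean on, a step of a 1.0-fold lower number from compound 2 to compound 3 (0.00 log units; within the scatter) is expected, that is none beyond the scatter, with a wide range. Compound 3 is therefore estimated at 7000 nM, between 2000 nM and 25000 nM.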

Compound 3, half-maximal inhibitory concentration: 5480 nM
For compound 3 the middle estimate is 1.3-fold (0.11 log units) above the measured one; the range from low to high includes it.
By their numbers in this assay, from the lowest: compounds 3 and 2 (each within the scatter of the next); then compound 1.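

In this assay, exchanging the (1-((oxiran-2-yl)methyl)pyrrolidin-2-yl)methyl group on the aromatic nitrogen for 1-((oxiran-2-yl)methyl)pyrrolidin-3-yl gives a 1.3-fold lower number from compound 2 to compound 3 (0.11 log units; within the scatter), so this position accepts that change with no step beyond the scatter. The wider exchange gives a 2.6-fold lower number from compound 1 to compound 3 (0.42 log units; beyond the scatter), but it alters both the link and the oxiran-2-yl group, so it cannot be credited to either alone. No evidence at hand explains these numbers. Still open, going by these compounds, is how 1,2-dihydroxyethyl would behave on the pyrrolidin-3-yl group, and what an amide or a longer chain would do in place of oxiran-2-yl.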